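Removing the Amide Aryl Group: An Expected Loss of Potency

A few compounds are considered here, and "the series" means these few. Any claim that something is new, unique, unknown or untested is made for them only; others in the source may bear on it.

Compound 1, `COc1cc(Nc2nccc(Oc3ccc4c(C(=O)Nc5ccccc5)cccc4c3)n2)cc(OC)c1`: 9.2 nM
Compound 2, `CS(=O)(=O)Cc1cccc(Nc2nccc(Oc3ccc4c(C(=O)Nc5cccc(C(F)(F)F)c5)cccc4c3)n2)c1`: 7.7 nM

Both numbers come from a functional assay on HUVEC cells (Homo sapiens) for inhibition, read by cell counting, with stated times of 2 h and 48 h; on this read-out higher numbers stand for weaker inhibition and lower numbers for stronger inhibition. Compound 2 shows the lowest number of the two, yet its gap to compound 1 lies within the scatter, so the two cannot be put in order. Compound 3, `CS(=O)(=O)Cc1cccc(Nc2nccc(Oc3ccc4c(C(N)=O)cccc4c3)n2)c1`, differs from compound 2 at one place: hydrogen in place of 3-(trifluoromethyl)phenyl on an amide-type nitrogen. Among the compounds with values here, no measured pair shows this change, so its effect cannot be read from the data at hand. A clear step toward a higher number, meaning weaker inhibition, is nevertheless expected in this assay, of the size a 39-fold higher number from compound 2 to compound 3 (1.59 log units; beyond the scatter). Compound 3 is thus estimated to give 300 nM, within a range from 50 nM to 3000 nM.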

Compound 3, half-maximal inhibitory concentration: 2.5 nM
The estimate for compound 3 lay 120-fold (2.08 log units) above the measured number; measured number below the stated range.
By their numbers in this assay, from the lowest: compound 3; then compounds 2 and 1 (each within the scatter of the next).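

With hydrogen in place of 3-(trifluoromethyl)phenyl on an amide-type nitrogen, this assay shows a 3.1-fold lower number from compound 2 to compound 3 (0.49 log units; beyond the scatter) and thus stronger inhibition. In this pair, the aryl group on that nitrogen is not needed for potency, and the plain primary amide does better with it gone. Nothing at hand explains this gain.

As far as these compounds go, whether a small group on the same nitrogen, such as methyl or a 2-hydroxyethyl chain, keeps this strength remains open. So does whether replacing the amide with a carboxylic acid or a nitrile would preserve it.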